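From 4-carboxybutyl to 1-carboxy-1-methylethyl: working notes

The source may hold more compounds than are shown below. What is called first, only, known or untested is meant among the compounds shown, and "the series" means these compounds.

Measured in a physicochemical assay for lipophilicity, read by HPLC, at pH 7.4; a higher number here means a more lipophilic compound, a lower number a more polar compound:
- compound 1 `O=C(O)CN1CCC(Oc2ccc([C@H]3CC[C@]4(CC3)OOC3(O4)C4CC5CC(C4)CC3C5)cc2)CC1`: "not determined" (no result reported)
- compound 2 `O=C(O)CCCCOc1ccc([C@H]2CC[C@]3(CC2)OOC2(O3)C3CC4CC(C3)CC2C4)cc1`: 4

Among the measured compounds shown here, compound 2, at 4, carries the only number so far, so it cannot be ranked against anything. The next entry, compound 3 `CC(C)(Oc1ccc([C@H]2CC[C@]3(CC2)OOC2(O3)C3CC4CC(C3)CC2C4)cc1)C(=O)O`, keeps the shared core and differs from compound 2 in one group: 1-carboxy-1-methylethyl in place of 4-carboxybutyl on an oxygen on an aromatic ring. In words, 1-carboxy-1-methylethyl stands in place of 4-carboxybutyl on an oxygen on an aromatic ring. For the measured compounds named here, no measured pair shows what a change of this kind does in this assay, so the expectation rests on the structural change alone and remains uncertain. Starting from compound 2 at 4, a modest move to a lower reading is expected, somewhat beyond the scatter, an estimated a number 0.60 log units lower from compound 2 to compound 3 (beyond the scatter). Compound 3 is estimated at 3.4, with an expected range of 2.7 to 3.9.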

Compound 3, distribution coefficient: 3.1
The estimate for compound 3 lay 0.30 log units above the measured number, within the range that was stated.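

Among the compounds shown here, this is the first readable step: in this assay, 1-carboxy-1-methylethyl in place of 4-carboxybutyl on an oxygen on an aromatic ring gives a number 0.90 log units lower from compound 2 to compound 3 (beyond the scatter). The reading at this position therefore moves with the group on that oxygen, even though the two groups have the same hydrogen-bond donor and acceptor counts and differ by 6 heavy atoms against 7. Nothing available accounts for the size or direction of this step.

With a single pair, the contribution of chain length cannot be separated from that of branching, and a straight-chain 2-carboxyethyl group would bear on that question. Also open, as far as these compounds go, is whether the step holds when a primary amide or a tetrazole stands in place of the carboxylic acid.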